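The source may hold more compounds than are shown below. What is called first, only, known or untested is meant among the compounds shown, and "the series" means these compounds.

Measured so far:
Compound 1 `Cc1ccccc1N1CCN(C2=CC(=O)c3cccc(O)c3C2=O)CC1` gives 2800 nM
Compound 2 `O=C1C=C(N2CCC(c3ccccc3)CC2)C(=O)c2c(O)cccc21` gives 5400 nM

Both values come from a functional assay on HT-29 cells (Homo sapiens) for antiproliferative activity, read by MTT assay, with a stated time of 72 h (on this read-out lower numbers stand for stronger inhibition and higher numbers for weaker inhibition), and the two structures differ in more than one place. Compound 2 stands within the usual scatter of compound 1, so the two numbers cannot be told apart.

Compound 3 `Cc1ccccc1C1CCN(C2=CC(=O)c3cccc(O)c3C2=O)CC1` is compound 2 with methyl in place of hydrogen on an aromatic carbon. This turns phenyl into 2-methylphenyl, with the methyl ortho to a large group. Among the measured compounds shown here, no measured pair shows this change alone. For the measured compounds named here, the only guide is compound 1, which also carries 2-methylphenyl and gives 2800 nM in this assay, so no step beyond the scatter is expected. The expected size of the change is a 1.4-fold lower number from compound 2 to compound 3 (0.15 log units; within the scatter), a small move toward stronger inhibition at most. For compound 3 the estimated value is 3800 nM, with an expected range from 1600 nM to 9000 nM.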

Compound 3, half-maximal inhibitory concentration: 6700 nM
Beside the measured number, compound 3's estimate is 1.8-fold (0.25 log units) below it; low and high end bracket the measured number.
By their numbers in this assay, from the lowest: compounds 1, 2 and 3 (each within the scatter of the next, the first and the last beyond it).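

Adding methyl to the phenyl group in this assay gives a 1.2-fold higher number from compound 2 to compound 3 (0.09 log units; within the scatter) and so leaves the two compounds indistinguishable. Among the compounds shown here, this is the first pair that isolates the methyl, placed on an aromatic carbon ortho to a large group, and at this place the change has no effect that can be told from ordinary scatter. Compound 1 also carries 2-methylphenyl, but it differs from compound 2 in more than one place, so it could not show this, and no further evidence bears on the result.

A single methyl at a single place says little about other groups on this ring. Going by these compounds, whether a methoxy group, a chlorine atom or an amine on the same carbon would shift the number beyond the scatter remains open, as does the effect of methyl on the ring's other carbons.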